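A few compounds are considered here, and "the series" means these few. Any claim that something is new, unique, unknown or untested is made for them only; others in the source may bear on it.

In a functional assay on Caco-2 cells (Homo sapiens) for antiproliferative activity, read by MTT assay, with a stated time of 48 h (a lower number here means a stronger inhibitor, a higher number a weaker inhibitor), compound 1 `C=CCN(C)C(=O)c1ccc(C(CC)(CC)c2ccc(OCCC(O)(CC)CC)c(C)c2)n1CC` gives > 50000 nM, a limit of the assay and not a number. Compound 3 `CCC(C)C(NC(=O)c1ccc(C(CC)(CC)c2ccc(OCCC(O)(CC)CC)c(C)c2)n1CC)C(=O)O` gives 20000 nM, within the scatter of compound 2 `CCOC(=O)CN(C)C(=O)c1ccc(C(CC)(CC)c2ccc(OCCC(O)(CC)CC)c(C)c2)n1CC` at 30300 nM. Compound 4 `CCn1c(C(=O)N(C)CCO)ccc1C(CC)(CC)c1ccc(OCCC(O)(CC)CC)c(C)c1` differs from compound 3 by (2-hydroxyethyl)(methyl)amino in place of (1-carboxy-2-methylbutyl)amino on a carbonyl carbon, with (2-hydroxyethyl)(methyl)amino in place of (1-carboxy-2-methylbutyl)amino on a carbonyl carbon. Going by the values given here, three measured steps bear on this: an at least 1.6-fold lower number from compound 1 to compound 2 (0.21 log units; that floor lies within the scatter), an at least 2.5-fold lower number from compound 1 to compound 3 (0.39 log units; beyond the scatter) and a 1.5-fold lower number from compound 2 to compound 3 (0.18 log units; within the scatter). The closest comparison is compound 2, which also has a methyl on that amino nitrogen, and its step of a 1.5-fold lower number from compound 2 to compound 3 (0.18 log units; within the scatter) is small. The expected step is a 1.5-fold higher number from compound 3 to compound 4 (0.18 log units; within the scatter), so no change beyond the scatter is expected in this assay. The estimate for compound 4 is 30000 nM, with an expected range of 12000 nM to 50000 nM.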

Compound 4, half-maximal inhibitory concentration: 74 nM
Estimate against measurement, compound 4: 410-fold (2.61 log units) above; measured number outside the range, below it.
By their numbers in this assay, from the lowest: compound 4; then compounds 3 and 2 (each within the scatter of the next). At a limit, above all of these: compound 1.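

On the carbonyl carbon, the amide group alone can move the series far in this assay, with a 270-fold lower number from compound 3 to compound 4 (2.43 log units; beyond the scatter). With the methyl on the amide nitrogen kept, hydroxymethyl in place of ethoxycarbonyl gives a 410-fold lower number from compound 2 to compound 4 (2.61 log units; beyond the scatter), so a change at the chain end is enough. Hydroxymethyl in place of vinyl gives an at least 670-fold lower number from compound 1 to compound 4 (2.82 log units; beyond the scatter), a floor only, as compound 1 stands at a limit of the assay: the limit of > 50000 nM in this assay, at which 1 of the 4 values shown sits.

On these data alone, whether the hydroxyl itself is required remains open; a methoxy, an amine or a longer hydroxypropyl chain would test this. As far as these compounds go, the role of the methyl on the amide nitrogen also remains open, since a 2-hydroxyethyl amide retaining the amide hydrogen would be needed to separate it.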